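A Halogen Swap on the Anilino Nitrogen of Compound 3

The compounds below may be only part of what the source reports. "The series", "measured", "known", "first", "only" and "open" are said of these compounds alone.

Three compounds have numbers in a functional assay on NCI-H1975 cells (Homo sapiens) for inhibition, read by MTT assay, with a stated time of 72 h; a higher number here means a weaker inhibitor, a lower number a stronger inhibitor:
Compound 1 `O=C(CSc1nc(Nc2ccccc2)c2ccccc2n1)Nc1ccc(F)cc1` gives 16500 nM.
Compound 2 `O=C(CSc1nc(Nc2ccccc2)c2ccccc2n1)Nc1ccc(Cl)c(Cl)c1` gives 10400 nM.
Compound 3 `C=CC(=O)Nc1cccc(NC(=O)CSc2nc(Nc3cccc(F)c3)c3ccccc3n2)c1` gives 2030 nM.

Compound 3 stands lowest of the three; compound 2 is its nearest neighbour and compound 1 the furthest, and both gaps lie beyond the scatter. Compound 4 `C=CC(=O)Nc1cccc(NC(=O)CSc2nc(Nc3ccc(Cl)cc3)c3ccccc3n2)c1` differs from compound 3 in one place: 4-chlorophenyl in place of 3-fluorophenyl on a nitrogen on an aromatic ring, read one bond further out as (3-fluorophenyl)amino to (4-chlorophenyl)amino. Among the measured compounds shown here, the only measured step, a 1.6-fold lower number from compound 1 to compound 2 (0.20 log units; within the scatter), exchanges halogenated phenyls on the amide-type nitrogen and stays within the scatter, so it bears only loosely on an exchange at the other nitrogen. No step beyond the scatter is expected here. Compound 4 is therefore estimated at 2500 nM, with a range from 800 nM to 8000 nM. The expected step is then a 1.2-fold higher number from compound 3 to compound 4 (0.09 log units; within the scatter).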

Compound 4, half-maximal inhibitory concentration: 7580 nM
Beside the measured number, compound 4's estimate is 3.0-fold (0.48 log units) below it; the range from low to high includes it.
By their numbers in this assay, from the lowest: compound 3; then compounds 4, 2 and 1 (each within the scatter of the next, the first and the last beyond it).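

Unlike the earlier step between halogenated phenyls on the amide-type nitrogen, this exchange on the nitrogen on an aromatic ring gives a change beyond the scatter in this assay: a 3.7-fold higher number from compound 3 to compound 4 (0.57 log units; beyond the scatter). The group on this nitrogen therefore matters to the read-out, with 3-fluorophenyl giving the lower number of the pair. Nothing available explains this step.

The change alters both the halogen and where it sits on the phenyl, and these two changes cannot be told apart here. A 3-chlorophenyl group on this nitrogen would separate them, while an aminophenyl group would test a non-halogen substituent.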